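Removing the Boc group: predicting compound 4 from a stereoisomer pair

This account rests on a few compounds, and the source may have more. Where it says the series, first, only, none or still open, it means among the compounds named here.

Of the compounds shown here, three sharing one core have been tested in a functional assay on HCC827 cells (Homo sapiens) for antiproliferative activity, read by MTT assay, with a stated time of 72 h; on this read-out higher numbers stand for weaker inhibition and lower numbers for stronger inhibition. Compound 1 `CN1CCN(c2ccc(Nc3ncc4nc(Nc5ccc(F)cc5)n([C@H]5CCNC5)c4n3)cc2)CC1` gives 1220 nM. Compound 2 `CN1CCN(c2ccc(Nc3ncc4nc(Nc5ccc(F)cc5)n([C@H]5CCN(C(=O)OC(C)(C)C)C5)c4n3)cc2)CC1` gives 580 nM, and compound 3 `CN1CCN(c2ccc(Nc3ncc4nc(Nc5ccc(F)cc5)n([C@@H]5CCN(C(=O)OC(C)(C)C)C5)c4n3)cc2)CC1` gives 27 nM. Compounds 2 and 3 are built from the same atoms and bonds (the two compounds have the same atoms and bonds and differ only in configuration as drawn: 1 of 1 stereo elements differ; a stereocentre at a saturated ring carbon is drawn S in compound 2 and R in compound 3), yet the step of a 21-fold lower number from compound 2 to compound 3 (1.33 log units; beyond the scatter) is large; that compounds 2 and 3 differ only in their drawn configuration the fact that compounds 2 and 3 differ only in the configuration as drawn is the one fact that separates them.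

Compound 4 `CN1CCN(c2ccc(Nc3ncc4nc(Nc5ccc(F)cc5)n([C@@H]5CCNC5)c4n3)cc2)CC1` has not yet been measured. It differs from compound 3 by hydrogen in place of tert-butoxycarbonyl on an amine nitrogen in a ring. The same change has already been made once, from compound 2 to compound 1 (hydrogen in place of tert-butoxycarbonyl on an amine nitrogen in a ring), where it produced a 2.1-fold higher number from compound 2 to compound 1 (0.32 log units; beyond the scatter). The two places where the change occurs are described in identical words, so it is the same change made on the other drawn configuration.

Starting from compound 3 in this assay, compound 4 is therefore expected to show a step of about a 2.1-fold higher number from compound 3 to compound 4 (0.32 log units; beyond the scatter), resting on compound 2 to compound 1 a 2.1-fold higher number from compound 2 to compound 1 (0.32 log units; beyond the scatter). Compound 4 is estimated at 57 nM, most likely between 20 nM and 160 nM.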

Compound 4, half-maximal inhibitory concentration: 300 nM
Beside the measured number, compound 4's estimate is 5.3-fold (0.72 log units) below it; the measured number lies above the stated range.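

Removing the tert-butoxycarbonyl group raises the number on both drawn configurations in this assay, but the size of the step does not carry over, with an 11-fold higher number from compound 3 to compound 4 (1.05 log units; beyond the scatter) on the R configuration, and the two steps clearly differ: the same change on two cores in this assay, a 2.1-fold higher number (0.32 log units; beyond the scatter) from compound 2 to compound 1 and an 11-fold higher number (1.05 log units; beyond the scatter) from compound 3 to compound 4, 5.3-fold (0.72 log units) apart, beyond the scatter of two such steps The choice of configuration also matters less once the group is gone, shrinking from a 21-fold lower number from compound 2 to compound 3 (1.33 log units; beyond the scatter) to a 4.1-fold lower number from compound 1 to compound 4 (0.61 log units; beyond the scatter), with the R configuration still giving the lower number: the fact that compounds 1 and 4 differ only in the configuration as drawn The step of a 1.9-fold lower number from compound 2 to compound 4 (0.29 log units; within the scatter) changes both the group and the configuration, so it isolates neither, and these four compounds show only that the direction held, not why the size differed or whether any rule extends to other cores.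

Going by these compounds, whether a methoxycarbonyl group, an acetyl amide or a simple methyl on that ring nitrogen would behave like tert-butoxycarbonyl or like hydrogen on either configuration remains open. So does whether the same pattern would appear in other cell lines.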